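Replacing phenyl with hydrogen on the side chain

This account rests on a few compounds, and the source may have more. Where it says the series, first, only, none or still open, it means among the compounds named here.

In a functional assay on KB cells (Homo sapiens) for cytotoxicity (a lower number here means a stronger inhibitor, a higher number a weaker inhibitor), compound 1 (`CCOCn1cc(C#N)c2c(N)ncnc21`) gives > 100000 nM, which is a limit and not a number. Compound 2 (`COCCOCn1cc(C#N)c2c(N)ncnc21`) gives > 100000 nM, again a limit. Compound 3 (`N#Cc1cn(Cc2ccccc2)c2ncnc(N)c12`) gives > 100000 nM, also a limit. Compound 3 therefore stands with the other two at the limit of > 100000 nM in this assay, at which 3 of the 3 values shown sit.

Compound 4 (`Cn1cc(C#N)c2c(N)ncnc21`) changes the side chain: hydrogen in place of phenyl on a saturated chain carbon bound to an aromatic nitrogen. The measured steps bearing on this change are a step that the two limits leave unreadable from compound 1 to compound 3 and a step that the two limits leave unreadable from compound 2 to compound 3, and neither has a readable size. They give no reason to expect a gain in this assay, and no direction is favoured. The expected change is small: a number no higher from compound 3 to compound 4 (the limit leaves the size open). For compound 4 the estimated value is 100000 nM, with an expected range of 30000 nM to 300000 nM.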

Compound 4, half-maximal inhibitory concentration: > 100000 nM
Compound 4: no number, only a limit; the forecaster's own chance of this, stated with the estimate: 85%; the middle value sits exactly at the limit.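

No step between compound 4 and compound 1, compound 2 or compound 3 can be read in this assay, as every result is a limit and not a number: the limit of > 100000 nM in this assay, at which 4 of the 4 values shown sit.

The compounds shown leave open whether these side chains differ at all in this assay.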